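This account rests on a few compounds, and the source may have more. Where it says the series, first, only, none or still open, it means among the compounds named here.

Measured compounds in a functional assay on HeLa cells (Homo sapiens) for inhibition, read by CCK-8 assay, with a stated time of 48 h; a higher number here means a weaker inhibitor, a lower number a stronger inhibitor:
- compound 1 `COc1ccc(-c2cc3nccc(-c4cc(OC)c(OC)c(OC)c4)n3n2)cc1N`: 283 nM
- compound 2 `COc1cc(-c2ccnc3cc(-c4ccc(Cl)cc4)nn23)cc(OC)c1OC`: 1490 nM
- compound 3 `COc1cc(-c2ccnc3cc(-c4ccc5c(ccn5C)c4)nn23)cc(OC)c1OC`: 19 nM

Within these three numbers compound 1 stands second highest. Its nearest neighbour is compound 2, reached by a 5.3-fold higher number from compound 1 to compound 2 (0.72 log units; beyond the scatter); the furthest is compound 3, reached by a 15-fold lower number from compound 1 to compound 3 (1.17 log units; beyond the scatter).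

Compound 4 `COc1cc(-c2ccnc3cc(-c4ccc(F)cc4)nn23)cc(OC)c1OC` is the next member. It differs from compound 1 in one place: 4-fluorophenyl in place of 3-amino-4-methoxyphenyl on an aromatic carbon. Of the measured steps, only a 5.3-fold higher number from compound 1 to compound 2 (0.72 log units; beyond the scatter) bears directly on this change: 4-chlorophenyl, like 4-fluorophenyl, is a substituted phenyl with no hydrogen-bond donor or acceptor, replacing the same 3-amino-4-methoxyphenyl at the same aromatic carbon. The steps to compound 3 concern 1-methyl-1H-indol-5-yl and do not inform this change. The 4-chlorophenyl analogue, compound 2, gives 1490 nM, a weakening beyond the scatter, and a 4-fluorophenyl group is expected to behave in the same direction and of similar size, though the two halogens are not interchangeable and the uncertainty is wide.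

For compound 4 the expected value is 1500 nM, with a range of 450 nM to 5000 nM. This expectation corresponds to a step of a 5.3-fold higher number from compound 1 to compound 4 (0.72 log units; beyond the scatter).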

Compound 4, half-maximal inhibitory concentration: 5840 nM
Compound 4: middle estimate off by 3.9-fold (0.59 log units), on the low side, outside the stated range (above it).
By their numbers in this assay, from the lowest: compound 3; then compound 1; then compound 2; then compound 4.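

Working notes: in this assay, 4-fluorophenyl in place of 3-amino-4-methoxyphenyl costs more than the 4-chlorophenyl result alone indicated (a 21-fold higher number from compound 1 to compound 4 (1.31 log units; beyond the scatter)), and the two halogens prove not to be interchangeable at this position (a 3.9-fold higher number from compound 2 to compound 4 (0.59 log units; beyond the scatter)). The span across this aromatic carbon also widens, with the largest step yet separating the 1-methyl-1H-indol-5-yl and 4-fluorophenyl groups (a 310-fold higher number from compound 3 to compound 4 (2.49 log units; beyond the scatter)), so a single change on this ring can move the number a long way. No measurement at hand explains this order of groups.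

Still open, on these data alone, is how the amino and methoxy groups of compound 1 each contribute, which a plain 3-aminophenyl or 4-methoxyphenyl group would separate. Also open, as far as these compounds go, are the 4-bromophenyl and unsubstituted phenyl groups, and whether the 1H-indol-5-yl group without its methyl holds the level of compound 3.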